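This account rests on a few compounds, and the source may have more. Where it says the series, first, only, none or still open, it means among the compounds named here.

Measured so far in a physicochemical assay for lipophilicity, read by HPLC, at pH 7.5; on this read-out lower numbers stand for lower lipophilicity and higher numbers for higher lipophilicity:
- compound 1 `CCOc1ccccc1-c1ccc(-c2nc3cnccc3c(N[C@H](CC)C(=O)N(C)C)c2C#N)cc1` gives 3.7
- compound 2 `CCOc1ccccc1-c1ccc(-c2nc3cnccc3c(N[C@H](CC)C(=O)NS(C)(=O)=O)c2C#N)cc1` gives 2.2
- compound 3 `CCOc1ccccc1-c1ccc(-c2nc3cnccc3c(C[C@H](C)C(N)=O)c2C#N)cc1` gives 3

Compound 3 stands second highest of the three, with compound 1 higher and compound 2 lower, both gaps beyond the scatter. Compound 4 `CCOc1ccccc1-c1ccc(-c2nc3cnccc3c(NC(COC)C(N)=O)c2C#N)cc1` is still unmeasured. It carries (1-carbamoyl-2-methoxyethyl)amino in place of 2-carbamoylpropyl on an aromatic carbon, ortho to a cyano group (1-carbamoyl-2-methoxyethyl)amino in place of 2-carbamoylpropyl on an aromatic carbon and otherwise matches compound 3.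

The nearest evidence is a number 0.70 log units lower from compound 1 to compound 3 (beyond the scatter) at this same place, a modest step. Taken in reverse, it points upward for compound 4, which like compound 1 has an amino group on the aromatic carbon. Against that, a number 1.50 log units lower from compound 1 to compound 2 (beyond the scatter) is a large step from a change on the carbonyl carbon alone, so compound 1, with its dimethylamino, is a loose guide. Going by the values given here, the modest a number 0.80 log units higher from compound 2 to compound 3 (beyond the scatter) adds little, and no measured step isolates the methoxy group.

No step beyond the scatter is expected in this assay here. The expected step is a number 0.10 log units lower from compound 3 to compound 4 (within the scatter) and is small. The estimated value for compound 4 is 2.9 with an expected range of 2.4 to 3.4.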

Compound 4, distribution coefficient: 2.8
Compound 4: the middle estimate sits 0.10 log units above what was measured, and the stated range covers the measured number.
By their numbers in this assay, from the lowest: compound 2; then compounds 4 and 3 (each within the scatter of the next); then compound 1.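

In this assay the swap at this aromatic carbon, ortho to a cyano group, gives a number 0.20 log units lower from compound 3 to compound 4 (within the scatter) even though (1-carbamoyl-2-methoxyethyl)amino counts more hydrogen-bond donors and acceptors than 2-carbamoylpropyl. An amino link at this place does not on its own match compound 1: on that nitrogen, 1-carbamoyl-2-methoxyethyl in place of 1-(dimethylcarbamoyl)propyl gives a number 0.90 log units lower from compound 1 to compound 4 (beyond the scatter) while the comparison with the methanesulfonamide gives a number 0.60 log units higher from compound 2 to compound 4 (beyond the scatter) and so places compound 4 between those two. No measurement at hand accounts for these steps.

The methoxy group, the primary carboxamide and the amino link are not separated by any single step among these compounds. Open too, from the compounds shown here alone, is how a hydroxymethyl group or a longer ether chain in place of the methoxymethyl part, or a carboxylic acid in place of the carboxamide, would read here.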